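A few compounds are considered here, and "the series" means these few. Any claim that something is new, unique, unknown or untested is made for them only; others in the source may bear on it.

Measured in a functional assay on PC-3 cells (Homo sapiens) for antiproliferative activity, read by MTT assay, with a stated time of 72 h; a higher number here means a weaker inhibitor, a lower number a stronger inhibitor:
compound 1, `CC/C=C/C(=O)Nc1cc2c(N3CCc4ccccc43)ncnc2cc1OC`: 5890 nM
compound 2, `COc1cc2ncnc(N3CCc4ccccc43)c2cc1NC(=O)/C=C/C(C)C`: 6530 nM
compound 3, `COc1cc2ncnc(N3CCc4ccccc43)c2cc1NC(=O)/C=C/CN1CCC(CO)CC1`: 2650 nM

Compound 3 gives the lowest of the three numbers in this assay. Its nearest neighbour is compound 1, separated by a 2.2-fold lower number from compound 1 to compound 3 (0.35 log units; beyond the scatter), and the wider gap is to compound 2, separated by a 2.5-fold lower number from compound 2 to compound 3 (0.39 log units; beyond the scatter). The remaining pair is a step within the scatter, a 1.1-fold higher number from compound 1 to compound 2 (0.04 log units; within the scatter), so compounds 1 and 2 cannot be ranked against each other.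

All three of these steps concern the chain on the amide. The change that leads to compound 4, `COc1cc2ncnc(N3CCCc4ccccc43)c2cc1NC(=O)/C=C/CN1CCC(CO)CC1`, sits elsewhere: 1,2,3,4-tetrahydroquinolin-1-yl in place of 2,3-dihydro-1H-indol-1-yl on an aromatic carbon. Among the measured compounds shown here, none of the measured steps alters this part of the core, so none of them bears directly on the step to compound 4. What they do show is the scale of the series: even the largest measured step was only modest, and the chain on the amide, which compound 4 keeps unchanged from compound 3, is the same one that gave compound 3 its place at the low end.

For the measured compounds named here, with no measured precedent for the change, compound 4 is expected to land close to compound 3, with a 1.0-fold higher number from compound 3 to compound 4 (0.01 log units; within the scatter) expected to remain within the scatter. The estimate for compound 4 in this assay is 2700 nM, with a range from 1000 nM to 7500 nM.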

Compound 4, half-maximal inhibitory concentration: 7150 nM
Compound 4: the middle estimate sits 2.6-fold (0.42 log units) below what was measured; measured number inside the range.
By their numbers in this assay, from the lowest: compound 3; then compounds 1, 2 and 4 (each within the scatter of the next).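

In this assay, this position on the aromatic carbon next to the ring nitrogen proves sensitive: going from the five-membered non-aromatic ring of 2,3-dihydro-1H-indol-1-yl to the six-membered non-aromatic ring of 1,2,3,4-tetrahydroquinolin-1-yl gives a 2.7-fold higher number from compound 3 to compound 4 (0.43 log units; beyond the scatter). Among the compounds shown here, the earlier compounds varied only the chain on the amide, so this is the first sign that the group on the core also moves the number, by a modest step beyond the scatter. It also shows that the 4-(hydroxymethyl)piperidin-1-yl chain shared by compound 3 and compound 4 does not by itself fix the result, and no measurement available here explains the step.

The compounds shown leave open whether the step would hold with the other amide chains, since this one pair carries a single chain and compound 3 is its only reference. They also leave open how the number would respond to a seven-membered ring in this place, to an open N-methylanilino group, or to a fluorine on the six-membered aromatic ring of the 1,2,3,4-tetrahydroquinolin-1-yl group.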